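A few compounds are considered here, and "the series" means these few. Any claim that something is new, unique, unknown or untested is made for them only; others in the source may bear on it.

Working notes on the series. The compounds share one core, seen in compound 1 `NC(=O)c1c(NC(=O)c2ccccc2Cl)sc2c1CCN(Cc1ccc(Cl)cc1)C2`, compound 2 `NC(=O)c1c(NC(=O)c2ccccc2Cl)sc2c1CCN(Cc1c(Cl)cccc1Cl)C2` and compound 3 `NC(=O)c1c(NC(=O)c2ccccc2I)sc2c1CCN(C(=S)Nc1ccccc1Cl)C2`. In a functional assay on HeLa cells (Homo sapiens) for antiproliferative activity, with a stated time of 24 h (a lower number here means a stronger inhibitor, a higher number a weaker inhibitor), compound 1 gives > 50000 nM, a limit of the assay and not a number. Compound 2 gives 28800 nM in this assay. Within the data shown here, the only measured step, an at least 1.7-fold lower number from compound 1 to compound 2 (0.23 log units; that floor lies within the scatter), rests on that limit and stays within the scatter. Compound 3 gives > 50000 nM in this assay, again a limit and not a number. Most of the series thus sits at the limit of > 50000 nM in this assay, at which 2 of the 3 values shown sit.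

Compound 4 `CSc1ccccc1C(=O)Nc1sc2c(c1C(N)=O)CCN(C(=S)Nc1ccccc1Cl)C2` differs from compound 3 by methylsulfanyl in place of iodo on an aromatic carbon. Among the measured compounds shown here, the single measured step concerns a different part of the molecule and gives no guide to the size or direction of this change, and no measured compound shows the entering group. Compound 4 is therefore expected to stand where compound 3 stands, with an expected step of a number no higher from compound 3 to compound 4 (the limit leaves the size open) in this assay. The estimate for compound 4 is 50000 nM, with a range from 15000 nM to 150000 nM, and the assay is expected most likely to return a limit again.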

Compound 4, half-maximal inhibitory concentration: 34700 nM
Compound 4: the middle estimate sits 1.4-fold (0.16 log units) above what was measured; low and high end bracket the measured number.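

Among these compounds, the exchange of 2-iodophenyl for 2-(methylsulfanyl)phenyl gives the series its first step at this position, with an at least 1.4-fold lower number from compound 3 to compound 4 (0.15 log units; that floor lies within the scatter) as its only reading, and because that step rests on a limit, its true size stays unknown. With the rest of compound 3 held fixed, this change brings a reading inside the measurable range of this assay, which no earlier compound with this group on the ring nitrogen had shown. Much of the series still stays out of that range: the limit of > 50000 nM in this assay, at which 2 of the 4 values shown sit.

From the compounds shown here alone, whether other groups at this position, such as an amine, a methoxy group or a carboxylic acid, would move the number beyond the scatter remains open, as does the effect of a longer chain on the sulfur. Also open, going by these compounds, is whether this exchange would read the same with the 2,6-dichlorophenyl group of compound 2 on the ring nitrogen.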